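From trifluoromethyl to chloro on a shared core

The compounds below may be only part of what the source reports. "The series", "measured", "known", "first", "only" and "open" are said of these compounds alone.

Values from an ADME assay on HepG2 cells (Homo sapiens) for cytotoxicity, read by neutral red uptake, with a stated time of 24 h (on this read-out lower numbers stand for higher toxicity in this test and higher numbers for lower toxicity in this test), for three compounds:
compound 1 `COc1ccc2nccc(NC(c3cccc(Cl)c3)c3ccc(CN4CCCC4)c(Cl)c3)c2c1` gives 12 uM
compound 2 `Clc1ccc(C(Nc2ccnc3cc(Cl)ccc23)c2ccc(Cn3ccnc3)cc2)cc1` gives 22 uM
compound 3 `Fc1cc(C(Nc2ccnc3cc(C(F)(F)F)ccc23)c2ccc(Cl)cc2)ccc1CN1CCCC1` gives 19 uM

Compound 3 at 19 uM lies within the usual scatter of both compound 2 and compound 1, so these numbers set no order among them. Compound 4 `Fc1cc(C(Nc2ccnc3cc(Cl)ccc23)c2ccc(Cl)cc2)ccc1CN1CCCC1` keeps everything in compound 3 except one group: chloro in place of trifluoromethyl on an aromatic carbon of the shared core. Within the data shown here, no pair of measured compounds isolates this change, so no direct step is available. Compound 2 also carries chloro at that place, differs elsewhere, and gives 22 uM in this assay within the scatter of compound 3. Nothing beyond the scatter is therefore expected, in either direction. The estimated move is a 1.1-fold lower number from compound 3 to compound 4 (0.02 log units; within the scatter) and it is expected to stay within that scatter. In this assay compound 4 is estimated at 18 uM with an expected range from 10 uM to 32 uM around that figure.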

Compound 4, half-maximal toxic concentration: 12 uM
Estimate against measurement, compound 4: 1.5-fold (0.18 log units) above, within the range that was stated.
By their numbers in this assay, from the lowest: compounds 1, 4, 3 and 2 (each within the scatter of the next).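

In this assay, among these compounds, chloro in place of trifluoromethyl on an aromatic carbon of the shared core gives a 1.6-fold lower number from compound 3 to compound 4 (0.20 log units; within the scatter) and so provides the first reading in which this one group alone differs. Among the compounds shown here, compound 2 also carries chloro at that place but differs elsewhere, so the earlier compounds could not isolate the exchange; this pair shows that, with the rest of the structure held, the two groups are not told apart in this test. No measurement is available here that bears on the cause of this result.

From the compounds shown here alone, whether an amine or a carboxylic acid on the same aromatic carbon would move the number beyond the scatter remains open. Going by these compounds, it is also open whether chloro and trifluoromethyl would read alike on the differently substituted frameworks of compound 1 or compound 2.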